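This account rests on a few compounds, and the source may have more. Where it says the series, first, only, none or still open, it means among the compounds named here.

Among the compounds with values here, in a functional assay on KB cells (Homo sapiens) for inhibition, read by MTT assay, with a stated time of 24 h, tested at 100 ug/mL (on this read-out higher numbers stand for more inhibition of growth at the one concentration tested and lower numbers for less inhibition of growth), compound 1 `O=C(CCCCC(S)CCS)NO` gives 58%, while compound 2 `O=C(CCCCC(S)CCS)Nc1ccccn1` gives 18.5%, the lower of the two numbers so far. Placing pyridin-2-yl in place of hydroxy on an amide-type nitrogen produces a large step: a number 39.5 percentage points lower from compound 1 to compound 2 (beyond the scatter).

Compound 3 `O=C(CCCCC(S)CCS)Nc1ccc(Br)cn1` keeps everything in compound 2 except for one small edit, bromo in place of hydrogen on an aromatic carbon. Within the data shown here, the only measured step bears on this edit indirectly. It shows that a change on the amide-type nitrogen can shift the result in this assay, but it involves a different change at a different place, so it does not set a size for adding bromo. Among the measured compounds shown here, no measured pair tests a bromo group.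

The best anchor is therefore compound 2 at 18.5%, the closest measured structure, and no shift beyond the scatter is the expected outcome, with only a tentative lean upward. The expected step is a number 4.5 percentage points higher from compound 2 to compound 3 (within the scatter). Compound 3 is estimated at 23%, with an expected range from 8% to 40%.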

Compound 3, percent growth inhibition at one concentration: 59.2%
Compound 3: the middle estimate sits 36.2 percentage points below what was measured; measured number outside the range, above it.
By their numbers in this assay, from the lowest: compound 2; then compounds 1 and 3 (each within the scatter of the next).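

In this assay the swap of hydrogen for bromo on this aromatic carbon gives a number 40.7 percentage points higher from compound 2 to compound 3 (beyond the scatter) and so shows that a single added heavy atom at this place, two atoms from the ring nitrogen and para to a large group, can change the read-out strongly. The earlier step concerned only the group on the amide-type nitrogen, so it could not show that the ring carbons also matter or that a change here could be this large. Nothing available explains why bromo has this effect on growth inhibition.

Still open, as far as these compounds go, is whether this step belongs to bromo in particular or whether a chloro group, a methoxy group or an amine on the same carbon would move the number in the same way. Equally open, from the compounds shown here alone, is whether bromo on another carbon of this ring would give a similar result, and whether the step would hold at concentrations other than the one tested.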